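Working notes on compound 3 in the cytotoxicity screen

The compounds below may be only part of what the source reports. "The series", "measured", "known", "first", "only" and "open" are said of these compounds alone.

Two compounds of the shared core have been run in an ADME assay on HeLa cells (Homo sapiens) for cytotoxicity, read by MTT assay; on this read-out higher numbers stand for lower toxicity in this test and lower numbers for higher toxicity in this test. Compound 1 `Cc1nc(-c2cccnc2)sc1-c1nnc(-c2ccccc2Cl)o1` gives only a limit of the assay there, > 100 ug/mL. Compound 2 `Cc1nc(-c2cccnc2)sc1-c1nnc(-c2ccc([N+](=O)[O-])cc2)o1` likewise gives only a limit, > 100 ug/mL. Compound 2 thus stands together with the other shown value at the limit of > 100 ug/mL in this assay, at which 2 of the 2 values shown sit. For the measured compounds named here, no measured step between these two compounds exists, so no size of effect can be drawn from them.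

Compound 3 `Cc1nc(-c2cccnc2)sc1-c1nnc(-c2ccc(O)cc2)o1` is not yet measured in this assay. It differs from compound 2 in one place: hydroxy in place of nitro on an aromatic carbon.

With both shown values sitting at the limit, the step from compound 2 to compound 3 is expected to be none beyond the scatter, estimated as a step that the limit leaves unreadable from compound 2 to compound 3. Compound 3 is accordingly expected to give 150 ug/mL, within a range from 60 ug/mL to 400 ug/mL, and will most likely return only a limit again.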

Compound 3, half-maximal cytotoxic concentration: > 100 ug/mL
Compound 3 was reported as a limit; the forecaster's own chance of this, stated with the estimate: 75%; the middle value is on the limit's open side.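

No step can be read from compound 2 to compound 3 or from compound 1 to compound 3 in this assay, since all three compounds give only a limit: the limit of > 100 ug/mL in this assay, at which 3 of the 3 values shown sit.

The compounds shown leave open how far apart these three compounds lie on this read-out.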